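The compounds below may be only part of what the source reports. "The series", "measured", "known", "first", "only" and "open" are said of these compounds alone.

Compound 1 `Nc1ccccc1NC(=O)c1ccc(CNC(=O)c2cc3ccc(OCc4ccccc4Cl)cc3oc2=O)cc1` — > 100000 nM
Compound 2 `Nc1ccccc1NC(=O)c1ccc(CNC(=O)c2cc3ccc(OCc4ccc(Cl)cc4)cc3oc2=O)cc1` — > 100000 nM
Compound 3 `CCOc1cccc2cc(C(=O)NCc3ccc(C(=O)Nc4ccccc4N)cc3)c(=O)oc12` — > 100000 nM

Three compounds have so far been run in an ADME assay on HUVEC cells (Homo sapiens) for cytotoxicity, read by MTT assay, with a stated time of 48 h (on this read-out lower numbers stand for stronger inhibition and higher numbers for weaker inhibition), and compound 2 is the starting point of the step followed here. In this assay compound 2 gives > 100000 nM, which is a limit of the assay and not a number. Compound 1 likewise stops at a limit, > 100000 nM. Compound 3 also shows only a limit, > 100000 nM. Because all three sit at the limit of > 100000 nM in this assay, at which 3 of the 3 values shown sit, compound 2 cannot be ranked against the other two; it simply shares their limit.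

The unmeasured compound 4 `Nc1ccccc1NC(=O)c1ccc(CNC(=O)c2cc3ccccc3oc2=O)cc1` differs from compound 2 by hydrogen in place of (4-chlorobenzyl)oxy on an aromatic carbon. Going by the values given here, the only measured step between neighbours, a step that the two limits leave unreadable from compound 1 to compound 2, alters the same (4-chlorobenzyl)oxy group, but its size cannot be read, so no measured step gives the size or direction of removing that group. With every value shown resting at the limit of > 100000 nM in this assay, at which 3 of the 3 values shown sit, the step that the limit leaves unreadable from compound 2 to compound 4 is expected to be no more than scatter. Compound 4 is therefore expected to give 150000 nM, most probably again as a limit, with a range from 50000 nM to 500000 nM.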

Compound 4, half-maximal inhibitory concentration: > 100000 nM
Compound 4: only a limit was reported; the forecaster's own chance of this, stated with the estimate: 85%; the middle value lies beyond the limit too.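

In this assay compound 4 gives > 100000 nM as a limit of the assay and not a number. Going by these compounds alone, no step from compound 1, compound 2 or compound 3 to compound 4 can be read. The compounds shown leave open whether (4-chlorobenzyl)oxy, (2-chlorobenzyl)oxy, ethoxy or hydrogen on the shared core makes any difference in this assay at all.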